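The compounds below may be only part of what the source reports. "The series", "measured", "known", "first", "only" and "open" are said of these compounds alone.

Measured so far in a functional assay on K562 cells (Homo sapiens) for cytotoxicity, read by flow cytometry, with a stated time of 72 h; a higher number here means a weaker inhibitor, a lower number a stronger inhibitor:
Compound 1 `Cc1ccc(S(=O)(=O)Cc2nc(Nc3ccccc3)c3cc([N+](=O)[O-])ccc3n2)cc1`: > 125000 nM
Compound 2 `Cc1ccc(S(=O)(=O)Cc2nc(Nc3cccc(Br)c3)c3cc([N+](=O)[O-])ccc3n2)cc1`: "nd(insoluble)" (no result reported)

Compound 1 gives > 125000 nM, which is a limit of the assay and not a number. Compound 2 has no number of its own, since its entry reads "nd(insoluble)" (no result reported) and no result was reported. The only mark on the scale beside it is the limit of > 125000 nM in this assay, at which 1 of the 2 values shown sits, so compound 2 cannot be placed. Compound 3 `Cc1ccc(S(=O)(=O)Cc2nc(Nc3cccc(Cl)c3)c3cc([N+](=O)[O-])ccc3n2)cc1` keeps the shared core and carries one change, chloro in place of bromo on an aromatic carbon. Within the data shown here, no measured pair shows what this swap does in this assay, so the expected step is none beyond the scatter, with no direction to name. A weak result is expected, and this rests only on compound 1, whose limit is > 125000 nM. Compound 3 is estimated at 80000 nM, within an expected range of 15000 nM to 125000 nM.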

Compound 3, half-maximal inhibitory concentration: > 125000 nM
Compound 3 gave a limit, no number; the forecaster's own chance of this, stated with the estimate: 55%; middle value at least 1.5-fold (0.19 log units) from the limit.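

Among these compounds, no step from compound 1 to compound 3 can be read, since in this assay both results are limits of the assay and not numbers: the limit of > 125000 nM in this assay, at which 2 of the 3 values shown sit.

The compounds shown leave open whether any change on the shared core gives a measurable effect on these cells, and what chloro in place of hydrogen does.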